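The source may hold more compounds than are shown below. What is called first, only, known or untested is meant among the compounds shown, and "the series" means these compounds.

Measured so far in a functional assay (aorta) with Rattus norvegicus as the target; a lower number here means a less potent compound, a higher number a more potent compound, by a factor of ten per unit of this negative logarithm:
compound 1 `COc1ccc2c(c1)C(n1ccccc1=O)=CC(C)(C)O2`, 6.55
compound 2 `CC1(C)C=C(n2ccccc2=O)c2cc(C(=O)c3ccc([N+](=O)[O-])cc3)ccc2O1`, 6.2
compound 3 `CC1(C)C=C(n2ccccc2=O)c2cc(C(=O)c3ccccc3F)ccc2O1`, 7.08

Compound 3 stands highest of the three, with a number 0.53 log units higher from compound 1 to compound 3 (beyond the scatter) and a number 0.88 log units higher from compound 2 to compound 3 (beyond the scatter) both beyond the scatter. Compound 4 `CC(=O)Oc1ccc2c(c1)C(n1ccccc1=O)=CC(C)(C)O2` has not yet been measured; it differs from compound 3 by acetoxy in place of (2-fluorophenyl)carbonyl on an aromatic carbon. The closest guide is the step of a number 0.53 log units higher from compound 1 to compound 3 (beyond the scatter), in which the (2-fluorophenyl)carbonyl group entered in place of methoxy; compound 4 instead carries acetoxy, a group without a ring, so that gain is expected to be largely undone. The step of a number 0.88 log units higher from compound 2 to compound 3 (beyond the scatter) exchanges one ring for another on the carbonyl and bears less directly. Compound 4 is therefore estimated at 6.5, with a range from 6 to 7. The expected step is a number 0.58 log units lower from compound 3 to compound 4 (beyond the scatter), a modest drop.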

Compound 4, logarithm of the reciprocal of the active concentration, log(1/C): 5.6
Beside the measured number, compound 4's estimate is 0.90 log units above it, outside the stated range (below it).
By their numbers in this assay, from the lowest: compound 4; then compound 2; then compound 1; then compound 3.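

Changing the group on this aromatic carbon can lower the number as well as raise it: in this assay there is a number 1.48 log units lower from compound 3 to compound 4 (beyond the scatter). The oxygen on the ring does not settle the outcome, since changing only what it carries, acetyl in place of methyl, gives a number 0.95 log units lower from compound 1 to compound 4 (beyond the scatter). Nothing available here explains these drops. Where an amine or a carboxylic acid on this carbon would fall remains open. So does whether a longer chain on the oxygen, such as butyryl, would behave like methyl or acetyl.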